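The compounds below may be only part of what the source reports. "The series", "measured", "known", "first", "only" and "open" are said of these compounds alone.

Working notes on the series. In a physicochemical assay for solubility, read by HPLC, with a stated time of 4 h, at pH 2 (on this read-out higher numbers stand for higher solubility and lower numbers for lower solubility), compound 2 `Cc1cc(/C=C/C#N)cc(C)c1Oc1cc(Nc2ccc(C#N)cc2)c(N)cc1C(=O)NN` gives 89.6 ug/mL. Compound 3 `Cc1cc(/C=C/C#N)cc(C)c1Oc1cc(Nc2ccc(C#N)cc2)c(N)cc1C(=O)N1CC1` gives 94.2 ug/mL and compound 1 `COCCOC(=O)c1cc(N)c(Nc2ccc(C#N)cc2)cc1Oc1c(C)cc(/C=C/C#N)cc1C` gives 1.64 ug/mL. Compound 2 thus stands within the scatter of one neighbour (a 1.1-fold higher number from compound 2 to compound 3 (0.02 log units; within the scatter)) and far from the other (a 55-fold higher number from compound 1 to compound 2 (1.74 log units; beyond the scatter), read the other way). Compound 4 `Cc1cc(/C=C/C#N)cc(C)c1Oc1cc(Nc2ccc(C#N)cc2)c(N)cc1C(=O)OCCC#N` carries 2-cyanoethoxy in place of aminoamino on a carbonyl carbon. The step that bears on this change is the one from a 2-methoxyethoxy on the carbonyl carbon to aminoamino, which was large in this assay; the parallel step to aziridin-1-yl was a 57-fold higher number from compound 1 to compound 3 (1.76 log units; beyond the scatter). Moving back from aminoamino to an oxygen-linked chain is therefore expected to give a large drop, a 30-fold lower number from compound 2 to compound 4 (1.48 log units; beyond the scatter). Compound 4 is estimated at 3 ug/mL, range 0.8 ug/mL to 15 ug/mL.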

Compound 4, solubility: 0.94 ug/mL
Estimate against measurement, compound 4: 3.2-fold (0.50 log units) above, within the range that was stated.
By their numbers in this assay, from the lowest: compounds 4 and 1 (each within the scatter of the next); then compounds 2 and 3 (each within the scatter of the next).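

In this assay, the two oxygen-linked chains on the carbonyl carbon are not separated (a 1.7-fold lower number from compound 1 to compound 4 (0.24 log units; within the scatter)), so cyano in place of methoxy on the saturated chain carbon gives no readable difference. Both nitrogen-linked groups stand far from 2-cyanoethoxy (a 95-fold lower number from compound 2 to compound 4 (1.98 log units; beyond the scatter)) (a 100-fold lower number from compound 3 to compound 4 (2.00 log units; beyond the scatter)), which places the large divide among these four compounds between oxygen and nitrogen attachment at the carbonyl carbon. Nothing at hand explains that divide. Still open, from the compounds shown here alone, is whether a simple primary amide or a carboxylic acid on the carbonyl carbon would sit with aminoamino and aziridin-1-yl, or with the oxygen-linked chains.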